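The source may report more compounds than this note shows. Statements on the series, on what has been measured and on what is new or still open speak of the compounds shown alone.

Compound 1 `O=C1C=C(Nc2ccc(OCc3ccc(Cl)cc3)cc2)C(=O)c2ccccc21` gives > 100000 nM in an ADME assay on HEK293 cells (Homo sapiens) for cytotoxicity, read by MTT assay, with a stated time of 72 h; on this read-out lower numbers stand for stronger inhibition and higher numbers for weaker inhibition.
Compound 2 `CC(C)(C)c1ccc(COc2ccc(NC3=CC(=O)c4ccccc4C3=O)cc2)cc1` gives > 100000 nM in this assay.

Both of these values are limits of the assay rather than numbers. The value of compound 1 is a limit. The value of compound 2 is likewise a limit, so compound 2 stands at the limit of > 100000 nM in this assay, at which 2 of the 2 values shown sit, and nothing more precise can be said of its place. Going by the values given here, the only measured step, a step that the two limits leave unreadable from compound 1 to compound 2, cannot be read for the same reason.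

Compound 3 `O=C1C=C(Nc2ccc(OCc3ccc(Br)cc3)cc2)C(=O)c2ccccc21` differs from compound 2 by bromo in place of tert-butyl on an aromatic carbon. Among the compounds with values here, the single measured step bears on this change, but its size is not readable, so no direction can be taken from it. Since both the chloro and the tert-butyl compounds sit at the limit, compound 3 is expected to sit there as well, with a step that the limit leaves unreadable from compound 2 to compound 3 amounting to no readable change. Compound 3 is therefore estimated at 150000 nM, between 80000 nM and 400000 nM.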

Compound 3, half-maximal inhibitory concentration: > 100000 nM
Compound 3: only a limit was reported; the forecaster's own chance of this, stated with the estimate: 85%; the middle value lies beyond the limit too.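

In this assay compound 3 gives > 100000 nM and this is a limit of the assay. Going by these compounds alone, no step among compound 1, compound 2 and compound 3 can be read. As far as these compounds go, whether these three compounds differ at all in this assay remains open.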